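Sulfonamide-amine series: naphthyl to methoxybenzyl change

A few compounds are considered here, and "the series" means these few. Any claim that something is new, unique, unknown or untested is made for them only; others in the source may bear on it.

Measured so far:
compound 1 `O=S(=O)(NCCCNCc1cccc2ccccc12)c1cc(C(F)(F)F)cc(C(F)(F)F)c1` gives 2800 nM
compound 2 `O=S(=O)(NCCCCCCNCc1ccc(Br)cc1)c1ccc2c(c1)OCC2` gives 13000 nM
compound 3 `O=S(=O)(NCCNCc1cccc2ccccc12)c1cc(C(F)(F)F)cc(C(F)(F)F)c1` gives 26000 nM

All numbers come from a functional assay on MIA PaCa-2 cells (Homo sapiens) for inhibition, read by MTT assay, with a stated time of 72 h; on this read-out lower numbers stand for stronger inhibition of growth and higher numbers for weaker inhibition of growth. Compound 1 stands lowest of the three; compound 2 sits well beyond the scatter above it, and compound 3 lies furthest away. Compounds 2 and 3 each differ from compound 1 in more than one place, so no single change is isolated among the measured set.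

Compound 4 `COc1ccccc1CNCCCNS(=O)(=O)c1cc(C(F)(F)F)cc(C(F)(F)F)c1` differs from compound 1 as follows: 2-methoxyphenyl in place of naphthalen-1-yl on a saturated chain carbon bound to an amine nitrogen. Among the compounds with values here, no measured pair shows this same change, so nothing in this assay fixes its size. A modest rise in the number is expected, with the estimated step from compound 1 to compound 4 being a 2.1-fold higher number from compound 1 to compound 4 (0.33 log units; beyond the scatter). Compound 4 is thus estimated at 6000 nM, within a range of 2500 nM to 15000 nM.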

Compound 4, concentration for 50% growth inhibition: 3100 nM
For compound 4 the middle estimate is 1.9-fold (0.29 log units) above the measured one; low and high end bracket the measured number.
By their numbers in this assay, from the lowest: compounds 1 and 4 (each within the scatter of the next); then compounds 2 and 3 (each within the scatter of the next).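

In this assay, 2-methoxyphenyl in place of naphthalen-1-yl on a saturated chain carbon bound to an amine nitrogen gives a 1.1-fold higher number from compound 1 to compound 4 (0.04 log units; within the scatter), so the two compounds cannot be told apart. At this position, on this chain and core, a single six-membered aromatic ring carrying methoxy serves as well as the two rings of naphthalen-1-yl. No available evidence bears on why these two groups match. Going by these compounds, whether the methoxy group contributes remains open, since plain phenyl or 2-hydroxyphenyl would be needed to show it. Also open, on these data alone, is whether this equivalence carries over to a longer chain.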